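Varying the ketone aryl group: notes on compounds 1 to 3

This account rests on a few compounds, and the source may have more. Where it says the series, first, only, none or still open, it means among the compounds named here.

Measured so far:
- compound 1 `O=C(/C=C/c1ccc2c(c1)B(O)OC2)c1ccc(-c2ccccc2)cc1`, 4900 nM in a functional assay on SK-OV-3 cells (Homo sapiens) for cytotoxicity, read by MTT assay, with a stated time of 48 h; on this read-out higher numbers stand for weaker inhibition and lower numbers for stronger inhibition
- compound 2 `Cn1cccc1C(=O)/C=C/c1ccc2c(c1)B(O)OC2`, 93600 nM in this assay

Compound 2 stands at the highest of the two numbers in this assay; its nearest neighbour, compound 1, gives a number lower by a gap well beyond the usual scatter. The two measured compounds differ in more than one place, so no single step can be read off from them; only the two values themselves are known.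

Compound 3 `Cc1ccc(C(=O)/C=C/c2ccc3c(c2)B(O)OC3)cc1` is not yet measured. Its change from compound 2 is 4-methylphenyl in place of 1-methyl-1H-pyrrol-2-yl on a carbonyl carbon. Compound 3 thus carries a six-membered carbon ring on the carbonyl, as compound 1 does, where compound 2 carries the five-membered ring. A step is expected from compound 2 to compound 3 of a 7.8-fold lower number from compound 2 to compound 3 (0.89 log units; beyond the scatter), downward, beyond the scatter, because compound 1 with its carbon-only aryl ketone gives 4900 nM in this assay. Compound 3 is estimated at 12000 nM in this assay, within a range of 4000 nM to 40000 nM.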

Compound 3, half-maximal inhibitory concentration: 3700 nM
Beside the measured number, compound 3's estimate is 3.2-fold (0.51 log units) above it, and the stated range ends above it.
By their numbers in this assay, from the lowest: compounds 3 and 1 (each within the scatter of the next); then compound 2.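

In this assay, for the compounds shown here, 4-methylphenyl in place of 1-methyl-1H-pyrrol-2-yl on a carbonyl carbon gives a 25-fold lower number from compound 2 to compound 3 (1.40 log units; beyond the scatter), the first single-place change that can be read, and it is a large one. Methyl in place of phenyl on an aromatic carbon gives a 1.3-fold lower number from compound 1 to compound 3 (0.12 log units; within the scatter), so this assay does not separate these two groups at that place, even though phenyl is much the larger. The compounds shown offer no measurement that explains either step.

On these data alone, whether the large step belongs to the ring size, the ring nitrogen or the methyl on that nitrogen stays open, since all three change together between the two groups. Also open, as far as these compounds go, is how an amine or a carboxylic acid in place of the methyl on that aromatic carbon would read in this assay.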